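The compounds below may be only part of what the source reports. "The series", "measured", "known", "first", "only" and "open" are said of these compounds alone.

Three compounds share one core and differ only in the aryl group attached to the carbonyl carbon. In a functional assay on Ehrlich cells (Mus musculus) for cytotoxicity, read by MTT assay, with a stated time of 48 h (a lower number here means a stronger inhibitor, a higher number a weaker inhibitor), compound 1 `COc1ccc(C(=O)c2cc(C)ccc2OCC(=O)NNC(=O)c2cc3ccccc3oc2=O)cc1` gives 38400 nM, compound 2 `Cc1ccc(OCC(=O)NNC(=O)c2cc3ccccc3oc2=O)c(C(=O)c2ccccc2Cl)c1` gives 45200 nM, and compound 3 `Cc1ccc(OCC(=O)NNC(=O)c2cc3ccccc3oc2=O)c(C(=O)c2cccc(Br)c2)c1` gives 66400 nM, the highest of the three numbers, although the steps of a 1.7-fold higher number from compound 1 to compound 3 (0.24 log units; within the scatter) and a 1.5-fold higher number from compound 2 to compound 3 (0.17 log units; within the scatter) both lie within the scatter, as does a 1.2-fold higher number from compound 1 to compound 2 (0.07 log units; within the scatter). Compound 4 `Cc1ccc(OCC(=O)NNC(=O)c2cc3ccccc3oc2=O)c(C(=O)c2ccc(Br)cc2)c1` differs from compound 3 by 4-bromophenyl in place of 3-bromophenyl on a carbonyl carbon. Going by the values given here, every measured step so far swapped the aryl group on that same carbonyl carbon without moving the number beyond the scatter, so the step expected here in this assay is a 1.1-fold lower number from compound 3 to compound 4 (0.04 log units; within the scatter), not beyond the scatter in either direction. Compound 4 is therefore estimated at 60000 nM, with a range from 30000 nM to 120000 nM.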

Compound 4, half-maximal inhibitory concentration: 87300 nM
Beside the measured number, compound 4's estimate is 1.5-fold (0.16 log units) below it, within the range that was stated.
By their numbers in this assay, from the lowest: compounds 1, 2, 3 and 4 (each within the scatter of the next, the first and the last beyond it).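

In this assay, exchanging 3-bromophenyl for 4-bromophenyl on the carbonyl carbon gives a 1.3-fold higher number from compound 3 to compound 4 (0.12 log units; within the scatter), and exchanging 2-chlorophenyl for 4-bromophenyl gives a 1.9-fold higher number from compound 2 to compound 4 (0.29 log units; within the scatter). Going by these compounds alone, the first step beyond the scatter at this position comes only with 4-bromophenyl in place of 4-methoxyphenyl, as a 2.3-fold higher number from compound 1 to compound 4 (0.36 log units; beyond the scatter), and it is modest. Nothing available here explains that gap. Still open, on these data alone, is whether an amine or a carboxylic acid on this aryl ring, or a pyridine ring in its place, would shift the number further.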